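Fluoro for methoxy in a cytotoxicity series at the limit

A few compounds are considered here, and "the series" means these few. Any claim that something is new, unique, unknown or untested is made for them only; others in the source may bear on it.

compound 1 `CC(=O)N[C@@H](CSC(=O)Nc1ccccc1F)C(=O)O`: > 200000 nM
compound 2 `COc1ccc(NC(=O)SC[C@H](NC(C)=O)C(=O)O)cc1`: > 200000 nM
compound 3 `CC(=O)N[C@@H](CSC(=O)Nc1cccc(Cl)c1)C(=O)O`: > 200000 nM

All three compounds were measured in a functional assay on OVCAR-3 cells (Homo sapiens) for cytotoxicity, read by MTT assay, with a stated time of 6 days; a higher number here means a weaker inhibitor, a lower number a stronger inhibitor. Compound 2 gives > 200000 nM, which is a limit and not a number. The other two values are limits as well, so the set cannot be ranked and compound 2 has no place in any order: the limit of > 200000 nM in this assay, at which 3 of the 3 values shown sit.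

Compound 4 `CC(=O)N[C@@H](CSC(=O)Nc1ccc(F)cc1)C(=O)O` has fluoro in place of methoxy on an aromatic carbon, para to a large group, relative to compound 2 (fluoro in place of methoxy on an aromatic carbon). Compound 1, which also carries a fluoro on its aromatic ring, gives > 200000 nM, again a limit. No step beyond the scatter is expected in this assay, in either direction, because of the limit of > 200000 nM in this assay, at which 3 of the 3 values shown sit. The estimated change is a number no higher from compound 2 to compound 4 (the limit leaves the size open). A report of compound 4 as a limit is the expected outcome. Compound 4 is estimated at 200000 nM, with an expected range from 100000 nM to 400000 nM.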

Compound 4, half-maximal inhibitory concentration: > 200000 nM
Compound 4 was reported as a limit (the forecaster's own chance of this, stated with the estimate: 90%); the middle value sits exactly at the limit.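

No step can be read from compound 2 to compound 4, as both values are limits and not numbers: the limit of > 200000 nM in this assay, at which 4 of the 4 values shown sit.

The compounds shown leave open how fluoro and methoxy compare on the aromatic ring, and which structure, if any, would give a measurable value in this assay.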